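The source may hold more compounds than are shown below. What is called first, only, known or untested is meant among the compounds shown, and "the series" means these compounds.

Measured compounds:
- compound 1, `N#C[C@@]1(NC(=O)[C@@H](CC(=O)N2CCOCC2)CC2CCC(c3ccccc3)CC2)CCN(C2CCCCC2)C1`: "not determined" (no result reported) in an assay on isolated protein for inhibition of cathepsin S (Homo sapiens); on this read-out higher numbers stand for weaker binding and lower numbers for tighter binding
- compound 2, `CN1CC[C@@](C#N)(NC(=O)[C@@H](CC(=O)N2CCOCC2)CC2CCCCC2)C1`: 161 nM

For the measured compounds named here, compound 1 carries no number in this assay, so compound 2 is the only compound with a measured value, and there is no step between measured compounds to anchor a comparison. In this assay compound 2 gives 161 nM; with nothing else measured, its standing in the series cannot be ranked.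

Compound 3, `N#C[C@@]1(NC(=O)[C@@H](CC(=O)N2CCOCC2)CC2CCCCC2)CCN(C2CCCCC2)C1`, is not yet measured. It differs from compound 2 by cyclohexyl in place of methyl on an amine nitrogen in a ring. Compound 1 also bears a cyclohexyl on that same ring nitrogen, but since it has no value, it offers no guidance on the effect of this change.

Going by the values given here, with no measured step of this kind available, the expected step of a 2.7-fold lower number from compound 2 to compound 3 (0.43 log units; beyond the scatter) is set at a modest size toward tighter binding and carries a broad range. Compound 3 is therefore estimated at 60 nM in this assay, with a range from 15 nM to 300 nM.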

Compound 3, dissociation constant: 17.8 nM
Compound 3: middle estimate off by 3.4-fold (0.53 log units), on the high side, and the stated range covers the measured number.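

In this assay, the amine nitrogen in the five-membered non-aromatic ring, two ring bonds from the ring atom that bears a cyano group, gives the series its first readable step: cyclohexyl in place of methyl brings a 9.0-fold lower number from compound 2 to compound 3 (0.96 log units; beyond the scatter). Binding at this position therefore depends on the group on that nitrogen, and the much larger cyclohexyl is not only accepted but gives the tighter binding of the pair, a point the unquantified compound 1 could not settle. No measurement at hand accounts for this gain.

With only methyl and cyclohexyl to compare, the compounds shown leave open whether the gain needs a carbon ring at all or would also appear with an open chain such as n-hexyl, and how it builds up through intermediate groups such as ethyl or isopropyl. They also leave open how this position responds to an aromatic ring such as phenyl, or to a cyclohexyl carrying a hydroxyl or an amine.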